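The source may hold more compounds than are shown below. What is called first, only, known or untested is meant among the compounds shown, and "the series" means these compounds.

In a functional assay on cells (T-cell line, Homo sapiens) for inhibition (on this read-out lower numbers stand for stronger inhibition and higher numbers for weaker inhibition), compound 3 `CCCCN1CCC(COC(c2ccccc2)c2ccccc2)CC1` gives 14000 nM. That lies within the scatter of compound 2 `CCCN1CCC(COC(c2ccccc2)c2ccccc2)CC1` at 17800 nM, whereas compound 1 `Clc1ccccc1CCCN1CCC(COC(c2ccccc2)c2ccccc2)CC1` gives 800 nM. Compound 4 `CCCCCCCCCCN1CCC(COC(c2ccccc2)c2ccccc2)CC1` keeps the shared core and extends the chain of compound 3: hexyl in place of hydrogen on a saturated chain carbon, four bonds along the chain from an amine nitrogen in a ring. Among the measured compounds shown here, two measured steps bear on this. Adding methyl to the chain gave a 1.3-fold lower number from compound 2 to compound 3 (0.10 log units; within the scatter), so that small extension changed nothing measurable. Placing 2-chlorophenyl there instead gave the large 18-fold higher number from compound 1 to compound 3 (1.24 log units; beyond the scatter). No chain as long as that of compound 4 has been measured, so a moderate move towards a lower number is expected, smaller than the gap to compound 1. The expected change is a 4.7-fold lower number from compound 3 to compound 4 (0.67 log units; beyond the scatter). For compound 4, the estimate is 3000 nM, within an expected range of 600 nM to 14000 nM.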

Compound 4, half-maximal inhibitory concentration: 2600 nM
Compound 4: middle estimate off by 1.2-fold (0.06 log units), on the high side, and the stated range covers the measured number.
By their numbers in this assay, from the lowest: compound 1; then compound 4; then compounds 3 and 2 (each within the scatter of the next).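

In this assay, lengthening the chain at this position does register, although the small step from compound 2 to compound 3 stayed within the scatter: hexyl brings a 5.4-fold lower number from compound 3 to compound 4 (0.73 log units; beyond the scatter) and heptyl brings a 6.8-fold lower number from compound 2 to compound 4 (0.84 log units; beyond the scatter). A plain saturated chain thus closes only part of the gap, as heptyl in place of 2-chlorophenyl still gives a 3.3-fold higher number from compound 1 to compound 4 (0.51 log units; beyond the scatter) at this position. No measured evidence explains these changes. Still open, as far as these compounds go, are how a chain of intermediate length or a longer chain would read, and whether a phenyl without the chlorine would match compound 1.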